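The source may hold more compounds than are shown below. What is called first, only, known or untested is meant among the compounds shown, and "the series" means these compounds.

Measured compounds in an assay on CHO cells for binding affinity to Substance-P receptor (Homo sapiens); on this read-out lower numbers stand for stronger inhibition and higher numbers for weaker inhibition:
- compound 1, `CCCCCN(CCCCC)C(=O)N1CCN(C(=O)N(c2ccccc2)c2ccccc2)[C@H](CO)C1`: 280 nM
- compound 2, `CCCCCN(CCCCC)C(=O)N1CCN(C(=O)N(c2ccccc2)c2ccccc2)[C@H](C(=O)NCCN(C)C)C1`: 55 nM
- compound 3, `CCCCCN(CCCCC)C(=O)N1CCN(C(=O)N(c2ccccc2)c2ccccc2)[C@H](C(=O)NCCN(CC)CC)C1`: 11 nM

Compound 3 gives the lowest number of the three in this assay. Its separation from the others is beyond the scatter in both cases: a 5.0-fold lower number from compound 2 to compound 3 (0.70 log units; beyond the scatter) and a 25-fold lower number from compound 1 to compound 3 (1.41 log units; beyond the scatter).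

Compound 4, `CCCCCN(CCCCC)C(=O)N1CCN(C(=O)N(c2ccccc2)c2ccccc2)[C@H](C(=O)N(C)CCN(C)C)C1`, is not yet measured. It differs from compound 3 in one place: (2-(dimethylamino)ethyl)(methyl)amino in place of (2-(diethylamino)ethyl)amino on a carbonyl carbon. The change has two parts. The first, diethylamino back to dimethylamino on the chain, is the reverse of a measured step, a 5.0-fold lower number from compound 2 to compound 3 (0.70 log units; beyond the scatter), and on its own would be expected to raise the number by about that amount, bringing compound 4 near compound 2. Within the data shown here, the second part, the methyl on the amide-type nitrogen, has no measured counterpart; compounds 1 to 3 all keep that position unsubstituted, so its effect is unknown and widens the range.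

Taking the reversal of the chain step as the main guide, compound 4 is expected to sit between compound 3 and compound 1, closer to compound 2, with a 6.4-fold higher number from compound 3 to compound 4 (0.80 log units; beyond the scatter) as the expected step. The estimate for compound 4 in this assay is 70 nM, with a range of 20 nM to 250 nM.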

Compound 4, half-maximal inhibitory concentration: 930 nM
The estimate for compound 4 lay 13-fold (1.12 log units) below the measured number; measured number above the stated range.
By their numbers in this assay, from the lowest: compound 3; then compound 2; then compound 1; then compound 4.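

In this assay, among these compounds, the amide-type nitrogen proves to be a position that the earlier compounds left untested, and methyl in place of hydrogen there gives a 17-fold higher number from compound 2 to compound 4 (1.23 log units; beyond the scatter), a larger step than the change at the chain end, a 5.0-fold lower number from compound 2 to compound 3 (0.70 log units; beyond the scatter). The gain over hydroxymethyl seen with the two unsubstituted carbamoyl side chains therefore does not extend to every carbamoyl: (2-(dimethylamino)ethyl)(methyl)carbamoyl in place of hydroxymethyl gives a 3.3-fold higher number from compound 1 to compound 4 (0.52 log units; beyond the scatter), so compound 4 goes against that pattern, and the full change from the diethylamino compound gives an 85-fold higher number from compound 3 to compound 4 (1.93 log units; beyond the scatter). No measurement at hand accounts for the loss on methylating this nitrogen.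

The compounds shown leave open whether the methyl costs as much when the chain ends in diethylamino, and whether an ethyl group on the amide-type nitrogen behaves like the methyl. As far as these compounds go, it also remains open whether the step from dimethylamino to diethylamino continues to a dipropylamino or piperidine end on the unsubstituted amide.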